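Swapping the amide tail for a small ring

A few compounds are considered here, and "the series" means these few. Any claim that something is new, unique, unknown or untested is made for them only; others in the source may bear on it.

Compound 1 `Cn1ncc(Cl)c1-c1cc(C(=O)N[C@@H]2CN[C@H](CC(=O)O)C[C@H]2c2ccc(Cl)c(Cl)c2)oc1Cl` is the starting point: in an assay for inhibition of RAC-alpha serine/threonine-protein kinase (Homo sapiens), read by HTRF, with a stated time of 1 h (a higher number here means a weaker inhibitor, a lower number a stronger inhibitor), compound 1 gives 1.94 nM. Compound 2 `Cn1ncc(Cl)c1-c1cc(C(=O)N[C@@H]2CN[C@H](CC(=O)NCC(O)CO)C[C@H]2c2ccc(Cl)c(Cl)c2)oc1Cl` carries a (2,3-dihydroxypropyl)amino group in place of the hydroxy on the carbonyl carbon, and in this assay compound 2 gives 3.13 nM. The change is a 1.6-fold higher number from compound 1 to compound 2 (0.21 log units; within the scatter), so compound 2 and compound 1 sit within the scatter of each other, and nothing separates them with confidence.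

Compound 3 `Cn1ncc(Cl)c1-c1cc(C(=O)N[C@@H]2CN[C@H](CC(=O)NC3CC3)C[C@H]2c2ccc(Cl)c(Cl)c2)oc1Cl` is the next move on the same amide: cyclopropyl in place of 2,3-dihydroxypropyl on an amide-type nitrogen. Among the measured compounds shown here, the only measured step that speaks to this position is the one from the acid to the dihydroxypropyl amide, a 1.6-fold higher number from compound 1 to compound 2 (0.21 log units; within the scatter), and it did not leave the scatter. That is thin ground, since a ring without donors or acceptors is a different kind of group from a hydroxylated chain, but it gives no reason to expect a large shift. Compound 3 is therefore estimated to land near 3 nM, with a range from 1.3 nM to 7 nM. The expected step is a 1.0-fold lower number from compound 2 to compound 3 (0.02 log units; within the scatter), that is, none beyond the scatter.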

Compound 3, half-maximal inhibitory concentration: 3.95 nM
Compound 3: the middle estimate sits 1.3-fold (0.12 log units) below what was measured; the measured number falls inside the stated range.
By their numbers in this assay, from the lowest: compounds 1, 2 and 3 (each within the scatter of the next, the first and the last beyond it).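

In this assay, the 2,3-dihydroxypropyl chain on the amide-type nitrogen gives way to cyclopropyl, a three-membered ring with 0 hydrogen-bond donors and 0 hydrogen-bond acceptors, and the step is a 1.3-fold higher number from compound 2 to compound 3 (0.10 log units; within the scatter) and so gives no sign of a real difference. The hydroxy groups of that chain are therefore not needed to keep the number in the low nanomolar range, at least on this core. Among the compounds shown here, measured against the free acid, however, the cyclopropyl amide gives the first step at this position to pass beyond the scatter, a 2.0-fold higher number from compound 1 to compound 3 (0.31 log units; beyond the scatter) and still only a modest one, whereas the dihydroxypropyl amide stayed within the scatter of the acid; nothing measured here gives a reason for either result.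

An open carbon chain such as propyl on the same nitrogen would help separate the effect of having a ring from that of losing the hydroxy groups, and the compounds shown do not include one. As far as these compounds go, a larger ring such as cyclobutyl or cyclohexyl, or a cyclopropyl ring bearing a hydroxy group, also remains open, so how far this position tolerates change is still unknown.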